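Imidazolyl to dimethylamino swap on an alkyne chain

This account rests on a few compounds, and the source may have more. Where it says the series, first, only, none or still open, it means among the compounds named here.

Compound 1 `CC(C#CCn1ccnc1)N1CCCC1=O` gives 2 mg/kg in a functional assay on the whole organism for antagonist activity, with Mus musculus as the target; a lower number here means that less compound is needed, a higher number that more compound is needed for the effect. Compound 2 `CC(C#CCN(C)C)N1CCCC1=O` differs from it by dimethylamino in place of 1H-imidazol-1-yl on a saturated chain carbon bound to a triple-bonded carbon. For compound 2 this assay reports only a limit, > 100 mg/kg. The change therefore produced an at least 50-fold higher number from compound 1 to compound 2 (1.69 log units; beyond the scatter). Compound 3 `CN1CCN(CC#CCn2ccnc2)C1=O` is built on another core; the difference between the two cores is not broken down here. For compound 3 this assay likewise reports only a limit, > 100 mg/kg. For the measured compounds named here, two of the three values known so far sit at the limit of > 100 mg/kg in this assay, at which 2 of the 3 values shown sit. Compound 4 `CN(C)CC#CCN1CCN(C)C1=O` is not yet measured and differs from compound 3 by dimethylamino in place of 1H-imidazol-1-yl on a saturated chain carbon bound to a triple-bonded carbon, which is the same change as from compound 1 to compound 2, at the same place. Compound 4 is expected to stay at or beyond the limit, an expected step that the limit leaves unreadable from compound 3 to compound 4, which rests on the fact that the same change gave an at least 50-fold higher number from compound 1 to compound 2 (1.69 log units; beyond the scatter) and that compound 3 already sits at the limit of > 100 mg/kg in this assay, at which 2 of the 3 values shown sit. The estimate for compound 4 in this assay is 300 mg/kg, between 100 mg/kg and 1000 mg/kg, most likely reported only as a limit.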

Compound 4, dose for half-maximal effect: > 10 mg/kg
Compound 4: no number, only a limit; the forecaster's own chance of this, stated with the estimate: 90%; the middle value lies beyond the limit too.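

Compound 3 and compound 4 both carry only limits in this assay, so the step between them cannot be read. The compounds shown leave open whether dimethylamino in place of 1H-imidazol-1-yl changes the dose needed on the core of compound 3 at all, and how either compound on this core would compare with compound 1.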